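This account rests on a few compounds, and the source may have more. Where it says the series, first, only, none or still open, it means among the compounds named here.

The three measured compounds, all examined in a functional assay on the whole organism for inhibition, with Cicer arietinum as the target, with a stated time of 7 days; on this read-out higher numbers stand for weaker inhibition and lower numbers for stronger inhibition:

compound 1, `S=C(SCc1nc2ccccc2[nH]1)N1CCOCC1`, gives 1890 nM;
compound 2, `S=C(SCc1nc2ccccc2[nH]1)N1CCCCC1`, gives 1660 nM;
compound 3, `O=C(CC(SC(=S)N1CCCCC1)c1ccccc1)c1ccccc1`, gives 1850 nM.

Compounds 1 and 2 share one core, and on it the change morpholin-4-yl in place of piperidin-1-yl on a thiocarbonyl carbon produced a step of a 1.1-fold higher number from compound 2 to compound 1 (0.06 log units; within the scatter) in this assay. Compound 3 sits on a different core; how the core of compound 3 differs from the core of compound 2 is not broken down here. In this assay the values of compound 3 and compound 2 lie within the scatter of each other, as do those of compound 3 and compound 1.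

The unmeasured compound 4, `O=C(CC(SC(=S)N1CCOCC1)c1ccccc1)c1ccccc1`, is obtained from compound 3 by morpholin-4-yl in place of piperidin-1-yl on a thiocarbonyl carbon. The same change, made at the same place, gave the step of a 1.1-fold higher number from compound 2 to compound 1 (0.06 log units; within the scatter) in this assay. On that step rests the expected step in this assay, estimated at a 1.1-fold higher number from compound 3 to compound 4 (0.04 log units; within the scatter). Compound 4 is therefore expected to give about 2050 nM in this assay, estimated to fall between 1000 nM and 4200 nM.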

Compound 4, half-maximal inhibitory concentration: 1650 nM
For compound 4 the middle estimate is 1.2-fold (0.09 log units) above the measured one; the measured number falls inside the stated range.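

In this assay, morpholin-4-yl in place of piperidin-1-yl on a thiocarbonyl carbon gave a 1.1-fold lower number from compound 3 to compound 4 (0.05 log units; within the scatter). Set beside the earlier step on the other core, the new step agrees with it: the same change on two cores in this assay, a 1.1-fold higher number (0.06 log units; within the scatter) from compound 2 to compound 1 and a 1.1-fold lower number (0.05 log units; within the scatter) from compound 3 to compound 4, 1.3-fold (0.11 log units) apart, within the scatter of two such steps. This shows that the change, carried from one core to the other, left the read-out within the scatter on both, but it does not show a consistent direction for the change, nor does it show how the change behaves on any further core, since two steps this small can only be said to match.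

The compounds shown leave open whether another group on the thiocarbonyl carbon, such as an open-chain diethylamino group or a piperazin-1-yl ring with its free amine, would move the number beyond the scatter. They also leave open whether the same exchange would stay as small on a core carrying a carboxylic acid.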